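A Methoxy Group Replaces Trifluoromethyl on a Boron Chalcone

The source may hold more compounds than are shown below. What is called first, only, known or untested is meant among the compounds shown, and "the series" means these compounds.

Compound 1 `O=C(/C=C/c1ccc2c(c1)B(O)OC2)c1ccc(C(F)(F)F)cc1` was examined in an ADME assay on L929 cells (Mus musculus) for cytotoxicity, read by resazurin assay, with a stated time of 72 h; a higher number here means a weaker inhibitor, a lower number a stronger inhibitor. In this assay compound 1 gives only a limit, > 10 ug/mL, and no exact number. Two related compounds do give numbers: compound 2 `COc1cccc(C(=O)/C=C/c2ccccc2)c1` gives 5.7 ug/mL in this assay, and compound 3 `COCOc1ccccc1C(=O)/C=C/c1ccc2c(c1)B(O)OC2` gives 9.02 ug/mL in this assay. Among the three values, compound 1 sits at the edge of what this assay can report (the limit of > 10 ug/mL in this assay, at which 1 of the 3 values shown sits), so its exact standing relative to compound 2 and compound 3 is not known.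

Compound 4 `COc1ccc(C(=O)/C=C/c2ccc3c(c2)B(O)OC3)cc1` has not yet been measured. It differs from compound 1 in one place: methoxy in place of trifluoromethyl on an aromatic carbon. Within the data shown here, no measured pair shows this exact change, so no measured step can be cited for it. A shift of no more than the usual scatter is expected in this assay, in either direction, since compound 2 and compound 3, which both carry a methoxy group, give numbers close to the limit reported for compound 1. Compound 4 is therefore expected to give about 10 ug/mL in this assay, with a range from 5 ug/mL to 20 ug/mL. The expected step of a number no higher from compound 1 to compound 4 (the limit leaves the size open) lies within the ordinary scatter of this assay.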

Compound 4, half-maximal inhibitory concentration: > 10 ug/mL
Compound 4 was reported as a limit; the forecaster's own chance of this, stated with the estimate: 55%; the middle value sits exactly at the limit.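

Among these compounds, compound 1 and compound 4 each give only a limit and not a number in this assay, and no step between them can be read: the limit of > 10 ug/mL in this assay, at which 2 of the 4 values shown sit. The compounds shown leave open whether methoxy in place of trifluoromethyl on an aromatic carbon shifts the value at all.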